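This account rests on a few compounds, and the source may have more. Where it says the series, first, only, none or still open, it means among the compounds named here.

Measured compounds:
compound 1 `COc1ccc(-c2cc(C(=O)N(C)C)ccn2)cc1S(=O)(=O)Nc1cccc(NCCNC(=O)c2cccc(C)c2)c1` — 93%
compound 2 `COc1ccc(-c2cccc(C(=O)N(C)C)n2)cc1S(=O)(=O)Nc1cccc(NCCNC(=O)c2cccc(C)c2)c1` — 100%
compound 3 `COc1ccc(-c2csc(C(=O)N(C)C)c2)cc1S(=O)(=O)Nc1cccc(NCCNC(=O)c2cccc(C)c2)c1` — 59%

In a functional assay on CHO-RD-HGA16 cells for agonist activity at Orexin/Hypocretin receptor type 1 (Homo sapiens), read by fluorescence and calcium flux, with a stated time of 30 min (a lower number here means a smaller maximal response, a higher number a larger maximal response), compound 3 stands lowest of the three numbers; the steps into it are a number 34 percentage points lower from compound 1 to compound 3 (beyond the scatter) and a number 41 percentage points lower from compound 2 to compound 3 (beyond the scatter), both beyond the scatter. Compounds 1 and 2 differ by a number 7 percentage points higher from compound 1 to compound 2 (within the scatter), within the scatter.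

Compound 4 `COc1ccc(-c2csc(C(=O)N(C)C)n2)cc1S(=O)(=O)Nc1cccc(NCCNC(=O)c2cccc(C)c2)c1` is not yet measured. Relative to compound 3 the change is 2-(dimethylcarbamoyl)-1,3-thiazol-4-yl in place of 5-(dimethylcarbamoyl)thiophen-3-yl on an aromatic carbon. Among the measured compounds shown here, no measured step covers this exact change. The two steps that bear on it are those into compound 3, which show that the 5-(dimethylcarbamoyl)thiophen-3-yl group gives a much smaller maximal response than either dimethylcarbamoyl-pyridin-2-yl group. Compound 4 keeps a five-membered ring but carries two hetero atoms, so a partial return toward the numbers of compounds 1 and 2 is expected, without reaching them. For compound 4 the estimated step is a number 16 percentage points higher from compound 3 to compound 4 (beyond the scatter). The estimate for compound 4 in this assay is 75%, with a range from 50% to 100%.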

Compound 4, largest response reached (Emax), in percent of the reference or control that the assay uses: 51%
For compound 4 the middle estimate is 24 percentage points above the measured one; the range from low to high includes it.
By their numbers in this assay, from the lowest: compounds 4 and 3 (each within the scatter of the next); then compounds 1 and 2 (each within the scatter of the next).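

In this assay, 2-(dimethylcarbamoyl)-1,3-thiazol-4-yl in place of 5-(dimethylcarbamoyl)thiophen-3-yl, para to the methoxy group, gives a number 8 percentage points lower from compound 3 to compound 4 (within the scatter), so the second hetero atom in the five-membered ring does not separate these two groups. The thiazole group stays well apart from both dimethylcarbamoyl-pyridin-2-yl groups, with a number 49 percentage points lower from compound 2 to compound 4 (beyond the scatter) and a number 42 percentage points lower from compound 1 to compound 4 (beyond the scatter), so across these four compounds the smaller maximal response goes with the five-membered ring, and none of the four goes against this. No evidence is at hand that would explain this difference between the ring types.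

Open, as far as these compounds go, is whether the dimethylcarbamoyl group is needed on the five-membered rings, which a carboxylic acid or a primary amide there would address. Also open, from the compounds shown here alone, is whether a pyrimidine ring carrying the same amide would give a response nearer that of the pyridine groups.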